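Swapping an amide-bearing arm for trifluoromethyl

The source may hold more compounds than are shown below. What is called first, only, known or untested is meant among the compounds shown, and "the series" means these compounds.

Measured so far:
Compound 1 `Cn1nc2c(=O)n(CC3(O)CCN(Cc4ccc(-c5ccco5)cc4Cl)CC3)cnc2c1-c1ccc(CNC(=O)C(F)(F)F)cc1`: 2060 nM
Compound 2 `Cn1nc2c(=O)n(CC3(O)CCN(Cc4ccc(-n5ccnc5)cc4Cl)CC3)cnc2c1-c1ccc(CN)cc1`: 228 nM
Compound 3 `Cn1nc2c(=O)n(CC3(O)CCN(Cc4ccc(-c5ncco5)cc4Cl)CC3)cnc2c1-c1ccc(CN)cc1`: 1120 nM

In an assay on isolated protein for inhibition of ubiquitin carboxyl-terminal hydrolase 7 (Homo sapiens), with stated times of 30 min and 2 h (on this read-out higher numbers stand for weaker inhibition and lower numbers for stronger inhibition), compound 1 gives the highest of the three numbers; its value sits within the scatter of that of compound 3, while compound 2 lies clearly lower. Within the data shown here, the only single-point step among the measured compounds is a 4.9-fold higher number from compound 2 to compound 3 (0.69 log units; beyond the scatter), and it concerns the ring on the other side of the shared core, not the position changed here.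

Compound 4 `Cn1nc2c(=O)n(CC3(O)CCN(Cc4ccc(-c5ccco5)cc4Cl)CC3)cnc2c1-c1ccc(C(F)(F)F)cc1` differs from compound 1 by trifluoromethyl in place of (((trifluoromethyl)carbonyl)amino)methyl on an aromatic carbon. Among the measured compounds shown here, no measured pair isolates this change: compounds 2 and 3 carry a different group at that position but also differ from compound 1 elsewhere, so their values cannot be read as a step for it. The replacement removes both the hydrogen-bond donor and the hydrogen-bond acceptor counted for the leaving group. With nothing to anchor the direction, compound 4 is expected to stay near compound 1, with a 1.5-fold higher number from compound 1 to compound 4 (0.16 log units; within the scatter) and an estimate of 3000 nM, between 800 nM and 12000 nM.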

Compound 4, half-maximal inhibitory concentration: 530 nM
Estimate against measurement, compound 4: 5.7-fold (0.75 log units) above; measured number below the stated range.
By their numbers in this assay, from the lowest: compound 2; then compound 4; then compounds 3 and 1 (each within the scatter of the next).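

In this assay, among these compounds, the step of a 3.9-fold lower number from compound 1 to compound 4 (0.59 log units; beyond the scatter) is the first reading of a single change at this position, on the six-membered aromatic ring of carbon only, para to a large group. It shows that with everything else in compound 1 held fixed, the (((trifluoromethyl)carbonyl)amino)methyl arm, with its hydrogen-bond donor and acceptor, can give way to the smaller trifluoromethyl without any loss of inhibition; the number in fact falls. No measurement here accounts for this gain.

Among the compounds shown here, compounds 2 and 3 differ from compounds 1 and 4 in more than one place, so no step to either can be read. Going by these compounds, whether the gain follows from losing the amide or from shortening the arm remains open, and a methyl, a nitrile or a plain aminomethyl group on the core of compound 4 would help to separate the two.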